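The compounds below may be only part of what the source reports. "The series", "measured", "known", "first", "only" and "open" are said of these compounds alone.

Measured so far in a functional assay on JAR cells (Homo sapiens) for inhibition, read by MTT assay, with a stated time of 72 h, tested at 10 uM; a lower number here means less inhibition, a higher number more inhibition at the concentration tested (going by the name of the read-out):
- compound 1, `CCOC(=O)C1=C(Nc2ccc(F)cc2)S/C(=C\c2ccc[nH]2)C1=O`, gives 61.5%
- compound 2, `CCOC(=O)C1=C(Nc2ccc(C(F)(F)F)cc2)S/C(=C\c2ccc[nH]2)C1=O`, gives 38.5%
- compound 3, `CCOC(=O)C1=C(Nc2ccc([N+](=O)[O-])cc2)S/C(=C\c2ccc[nH]2)C1=O`, gives 54.9%

Compound 3 stands second highest of the three numbers; its nearest neighbour is compound 1, a gap that is within the scatter, while compound 2 lies further off, with a number 16.4 percentage points higher from compound 2 to compound 3 (beyond the scatter).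

The next compound, compound 4, `CCOC(=O)C1=C(Nc2ccc(C)cc2)S/C(=C\c2ccc[nH]2)C1=O`, keeps the shared core and differs from compound 3 by methyl in place of nitro on an aromatic carbon.

Going by the values given here, two measured steps touch the same aromatic carbon. The step of a number 6.6 percentage points lower from compound 1 to compound 3 (within the scatter) exchanges fluoro for nitro and stays within the scatter. The step of a number 16.4 percentage points higher from compound 2 to compound 3 (beyond the scatter) exchanges trifluoromethyl for nitro and is beyond the scatter. Among the compounds with values here, no measured step places a methyl at this carbon, so there is no direct precedent for compound 4; the three substituents seen so far span a modest range, with fluoro and nitro close together and trifluoromethyl lower.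

On that footing the expected step in this assay is a number 0.1 percentage points higher from compound 3 to compound 4 (within the scatter), a change not beyond the scatter in either direction. Compound 4 is therefore estimated at 55%, within the range 35% to 72%.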

Compound 4, a percentage reported as inhibition, at one concentration (the size of the read-out at that concentration, not a potency): < 10%
Compound 4 gave a limit, no number (the forecaster's own chance of this, stated with the estimate: 2%); middle value at least 45 percentage points from the limit.
By their numbers in this assay, from the lowest: compound 2; then compounds 3 and 1 (each within the scatter of the next). At a limit, below all of these: compound 4.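

In this assay, the reading for compound 4 is a limit of the assay and not a number: the limit of < 10% in this assay, at which 1 of the 4 values shown sits. Even so, putting methyl on this aromatic carbon gives a number at least 44.9 percentage points lower from compound 3 to compound 4 (beyond the scatter), a number at least 51.5 percentage points lower from compound 1 to compound 4 (beyond the scatter) and a number at least 28.5 percentage points lower from compound 2 to compound 4 (beyond the scatter), so methyl stands apart from nitro, fluoro and trifluoromethyl at this position. The three earlier groups differed only modestly from one another, whereas this result shows that a single change on this carbon can take the reading down to the limit, and the position is more sensitive than those compounds alone suggested.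

On these data alone, whether this loss belongs to methyl alone or extends to other groups on the same carbon, such as ethyl, methoxy or an amine, stays open. With only these four groups, the compounds shown do not tell what sets the readings apart.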